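This account rests on a few compounds, and the source may have more. Where it says the series, first, only, none or still open, it means among the compounds named here.

Series notes. Compound 1 `CCN(CC(=O)NC[C@H]1O[C@H](OC)[C@@H](OS(=O)(=O)O)[C@@H](OS(=O)(=O)O)[C@@H]1OS(=O)(=O)O)C(=O)COS(=O)(=O)O` carries a sulfooxy group on the chain carbon next along from the carbonyl; in an assay on isolated protein for binding affinity to vascular endothelial growth factor A, long form (Homo sapiens), read by surface plasmon resonance (a higher number here means weaker binding, a lower number tighter binding), compound 1 gives 512000 nM. Within the data shown here, compound 2 `CCN(CC(=O)NC[C@H]1O[C@H](OC)[C@@H](OS(=O)(=O)O)[C@@H](OS(=O)(=O)O)[C@@H]1OS(=O)(=O)O)C(=O)CCCc1ccccc1` replaces that group with phenethyl and in this assay compound 2 gives 81000 nM, which is the lower of the two numbers measured so far; the step is a 6.3-fold lower number from compound 1 to compound 2 (0.80 log units; beyond the scatter).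

Compound 3 `CCN(CC(=O)NC[C@H]1O[C@H](OC)[C@@H](OS(=O)(=O)O)[C@@H](OS(=O)(=O)O)[C@@H]1OS(=O)(=O)O)C(=O)CCc1ccccc1` shortens the chain: phenyl in place of benzyl on a saturated chain carbon, two bonds along the chain from a carbonyl carbon. Among the measured compounds shown here, only one measured step touches this region, and it concerns exchanging sulfooxy for an aromatic-bearing chain, not the chain length itself. For the measured compounds named here, no measured pair separates the two chain lengths, so the size of the present step cannot be read from the data. Against that background the expectation for compound 3 in this assay is a step of a 1.2-fold higher number from compound 2 to compound 3 (0.09 log units; within the scatter), with no clear direction beyond the scatter. Compound 3 is therefore estimated at 100000 nM, within a range of 40000 nM to 250000 nM.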

Compound 3, dissociation constant: 596000 nM
Compound 3: middle estimate off by 6.0-fold (0.78 log units), on the low side; the whole stated range lies below it.
By their numbers in this assay, from the lowest: compound 2; then compounds 1 and 3 (each within the scatter of the next).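

Among these compounds, the first measured pair on chain length shows that this position is sensitive to it: phenyl in place of benzyl on a saturated chain carbon, two bonds along the chain from a carbonyl carbon, gives a clear loss (as a 7.4-fold higher number from compound 2 to compound 3 (0.87 log units; beyond the scatter) in this assay), which cancels the tighter binding of compound 2. With benzyl in place of sulfooxy on a saturated chain carbon bound to a carbonyl carbon, the step (as a 1.2-fold higher number from compound 1 to compound 3 (0.07 log units; within the scatter)) stays within the scatter, so an aromatic ring on this chain does not by itself set a compound apart from compound 1, and among these three only the chain of compound 2 does. Nothing at hand bears on why chain length counts here.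

Still open, on these data alone, is whether a longer chain than the 3-phenylpropyl of compound 2 tightens binding further or loses it again. Also open, as far as these compounds go, is whether the phenyl ring itself is needed at that length, or whether a cyclohexyl ring, an amine or a carboxylic acid on the same chain would serve as well.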